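A Cyanoguanidine in Place of a Thiourea

This account rests on a few compounds, and the source may have more. Where it says the series, first, only, none or still open, it means among the compounds named here.

Compound 2 `CC(C)(C)/N=C(\S)NCCCCn1nc(-c2ccccc2)ccc1=O` belongs to a set of three measured compounds that share a core and a four-carbon chain ending in a substituted amine. In a functional assay on the whole organism (stomach) with Rattus norvegicus as the target (on this read-out lower numbers stand for an effect already at smaller amounts and higher numbers for an effect only at larger amounts of compound), compound 2 gives > 100 mg/kg, which is a limit of the assay and not a number. Compound 1 `C/N=C(\S)NCCCCn1nc(C)ccc1=O` gives > 100 mg/kg in this assay, again only a limit. Compound 3 `C/N=C(/NC#N)NCCCCn1nc(-c2ccc(C)cc2)ccc1=O` gives > 100 mg/kg in this assay, likewise a limit. Among the compounds with values here, compound 2 therefore stands at the limit of > 100 mg/kg in this assay, at which 3 of the 3 values shown sit; no measured compound gives an actual number.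

Compound 4 `N#CNC(=N)NCCCCn1nc(-c2ccccc2)ccc1=O` has not been measured. It differs from compound 2 by a group of 5 heavy atoms (2 carbon, 3 nitrogen; no ring) in place of a group of 7 heavy atoms (5 carbon, 1 nitrogen, 1 sulfur; no ring), on an amine nitrogen, on an amine nitrogen whose other neighbour is a saturated chain carbon. Within the data shown here, no step between measured compounds is available as a guide, so the expected step is a step that the limit leaves unreadable from compound 2 to compound 4, that is, none beyond the scatter. Compound 4 is expected to give about 150 mg/kg in this assay, most likely again only as a limit, with a range from 50 mg/kg to 500 mg/kg.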

Compound 4, dose for half-maximal effect: 77.2 mg/kg
The estimate for compound 4 lay 1.9-fold (0.29 log units) above the measured number; measured number inside the range.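

In this assay, the position on the amine nitrogen turns out to be one where a change can bring a compound off the limit: a group of 5 heavy atoms in place of a group of 7 heavy atoms gives an at least 1.2-fold lower number from compound 2 to compound 4 (0.11 log units; that floor lies within the scatter). That step is only a floor, so its true size cannot be read, and it does not by itself separate compound 4 from compound 2 beyond the usual scatter. Even so, compound 4 is the only compound shown that gives an actual number, while the others remain at a limit of the assay: the limit of > 100 mg/kg in this assay, at which 3 of the 4 values shown sit.

Within the data shown here, no step links compound 4 to compound 1 or compound 3, so it remains open whether the same exchange would give a number with other groups on the shared core. Also open, on these data alone, is how a urea at this position, or a longer chain in place of the four-carbon chain, would read.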